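Two Inactive Pyrrolidinone Amides and a Pyridine Variant

The source may hold more compounds than are shown below. What is called first, only, known or untested is meant among the compounds shown, and "the series" means these compounds.

Measured so far:
compound 1, `O=C(NCc1ccccc1)[C@@H]1CCC(=O)N1Cc1ccccc1` — > 5000 nM
compound 2, `O=C(NCc1ccc(OCc2ccc(-c3nn[nH]n3)cc2)cc1)[C@@H]1CCC(=O)N1Cc1ccccc1` — > 5000 nM

Both compounds share a benzyl-substituted pyrrolidinone core carrying an amide. In an assay on HEK293 cells for inhibition of Ataxin-2 (Mus musculus), read by fluorescence and Amplex Red (on this read-out lower numbers stand for stronger inhibition and higher numbers for weaker inhibition), compound 1 gives > 5000 nM, which is a limit of the assay rather than a number. In this assay compound 2 likewise gives > 5000 nM, again a limit and not a measured value. So compound 2 stands at the edge of what this assay can report, a position described by the limit of > 5000 nM in this assay, at which 2 of the 2 values shown sit: neither of the two values shown is a real number, so no step between measured compounds can be drawn, and compound 2 cannot be placed above or below compound 1.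

Compound 3, `O=C(NCc1ccc(OCc2ccncc2)cc1)[C@@H]1CCC(=O)N1Cc1ccccc1`, differs from compound 2 in one place: pyridin-4-yl in place of 4-(2H-tetrazol-5-yl)phenyl on a saturated chain carbon bound to an oxygen on an aromatic ring. Since compound 2 only reached a limit in this assay, there is no measured size to build on. The expectation is that compound 3 stays in the same region, most likely again beyond the limit, with the estimated shift a step that the limit leaves unreadable from compound 2 to compound 3 being within the scatter. Compound 3 is therefore estimated at 9000 nM, within a range from 3000 nM to 40000 nM.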

Compound 3, half-maximal inhibitory concentration: > 5000 nM
Compound 3 ended at the assay's limit; the forecaster's own chance of this, stated with the estimate: 80%; the middle value does not contradict the limit.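

No step can be read among compound 1, compound 2 and compound 3, because each result is a limit of the assay and not a number: the limit of > 5000 nM in this assay, at which 3 of the 3 values shown sit. The compounds shown leave open whether any group on a saturated chain carbon bound to an oxygen on an aromatic ring would give a measurable value in this assay at all.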